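Dropping a hydroxy group in a cytotoxicity series

This account rests on a few compounds, and the source may have more. Where it says the series, first, only, none or still open, it means among the compounds named here.

Compound 1 `COc1ccc(-c2cn(-c3ccc(OC)cc3OC)nn2)cc1`: > 10000 nM
Compound 2 `COc1ccc(-n2cc(-c3ccc(OC)c(OC)c3)nn2)cc1O`: > 1000 nM
Compound 3 `COc1ccc(-c2cn(-c3ccc(OC)c(O)c3)nn2)cc1`: > 100 nM

In a functional assay on MDA-MB-231 cells (Homo sapiens) for cytotoxicity, read by MTT assay (on this read-out lower numbers stand for stronger inhibition and higher numbers for weaker inhibition), compound 3 gives > 100 nM, which is a limit of the assay rather than a number. Compound 2 likewise gives only a limit, > 1000 nM. Compound 1 gives > 10000 nM, again a limit. So none of the three values shown for compound 3 and its neighbours is a true number, and a step that the two limits leave unreadable from compound 2 to compound 3 cannot be read.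

Compound 4 `COc1ccc(-c2cn(-c3ccc(OC)cc3)nn2)cc1` has not yet been measured. It differs from compound 3 as follows: hydrogen in place of hydroxy on an aromatic carbon. For the measured compounds named here, the only measured step that touches this part of the structure is the one from compound 2 to compound 3, and its size is hidden by the two limits the limit of > 100 nM in this assay, at which 1 of the 3 values shown sits, and (the limit of > 1000 nM in this assay, at which 1 of the 3 values shown sits). Going by the values given here, no step therefore tells how much the loss of the hydroxy group should matter, in either direction.

With the evidence this thin, compound 4 is expected to give about 5000 nM in this assay, within 500 nM to 50000 nM, and the step from compound 3 is estimated as a step that the limit leaves unreadable from compound 3 to compound 4, with a high chance that only a limit is reported.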

Compound 4, half-maximal inhibitory concentration: > 100 nM
Compound 4: only a limit was reported; the forecaster's own chance of this, stated with the estimate: 70%; the middle value lies beyond the limit too.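

In this assay compound 4 gives > 100 nM, which is a limit and not a number. For the compounds shown here, compound 1 and compound 3 also give only limits, so no step from either to compound 4 can be read. On these data alone, whether swapping hydroxy for hydrogen changes cytotoxicity at all stays open.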